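A few compounds are considered here, and "the series" means these few. Any claim that something is new, unique, unknown or untested is made for them only; others in the source may bear on it.

Of the compounds shown here, two have been measured in a functional assay on DU-145 cells (Homo sapiens) for inhibition, read by MTT assay, with a stated time of 72 h; a lower number here means a stronger inhibitor, a higher number a weaker inhibitor. Compound 1 `O=C1C=C(N2CCN(c3ccc(Br)cc3)CC2)C(=O)c2ccccc21` gives > 50000 nM, which is a limit of the assay and not a number. Among the measured compounds shown here, compound 2 `O=C1C=C(N2CCN(c3ccccc3)CC2)C(=O)c2ccccc21` gives 9900 nM, the only actual number so far. The next compound is compound 3 `O=C1C=C(N2CCN(c3ccccc3Cl)CC2)C(=O)c2ccccc21`, and the change is chloro in place of hydrogen on an aromatic carbon, ortho to a large group. For the measured compounds named here, one measured step bears on this, an at least 5.0-fold lower number from compound 1 to compound 2 (0.70 log units; beyond the scatter), where hydrogen replaces bromo on an aromatic carbon. That step involves a different halogen at a different ring carbon, so it guides direction only loosely. Going by that step, a small move towards a higher number is expected in this assay, possibly within the scatter, and the expected step is a 1.5-fold higher number from compound 2 to compound 3 (0.18 log units; within the scatter). For compound 3 the estimated value is 15000 nM, with an expected range of 5000 nM to 50000 nM.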

Compound 3, half-maximal inhibitory concentration: 2900 nM
Estimate against measurement, compound 3: 5.2-fold (0.71 log units) above; measured number below the stated range.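

In this assay, a halogen on the phenyl ring carried by the amine nitrogen does not always raise the number: chloro ortho to a large group gives a 3.4-fold lower number from compound 2 to compound 3 (0.53 log units; beyond the scatter), the opposite direction to the bromo comparison. The two halogenated compounds also sit far apart, with an at least 17-fold lower number from compound 1 to compound 3 (1.23 log units; beyond the scatter). Compound 1 holds a limit of the assay and not a number, which leaves the size of that step open on one side: the limit of > 50000 nM in this assay, at which 1 of the 3 values shown sits.

Compound 1 and compound 3 differ in both the halogen and its ring carbon, and the compounds shown do not separate these two changes. Also open, from the compounds shown here alone, is how bromo would read in the place of chloro, and how a methyl, a methoxy or an amine would read there.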